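The source may report more compounds than this note shows. Statements on the series, on what has been measured and on what is new or still open speak of the compounds shown alone.

Measured compounds:
compound 1, `O=S(=O)(CC1=NCCO1)c1n[nH]cc1-c1ccc(Cl)cc1`: "not active" (no number reported)
compound 2, `Cc1ccc(C2CNN=C2S(=O)(=O)CC2=NCCS2)cc1`: 45.1%

Among the measured compounds shown here, in a functional assay, tested at 100 ug/mL (on this read-out lower numbers stand for a weaker effect and higher numbers for a stronger effect at the one concentration tested), compound 2 gives 45.1%, the only number reported. Compound 1 is reported in this assay as "not active" (no number reported) without a number, so compound 2 stands alone as a reference point. Compound 3, `O=S(=O)(CC1=NCCS1)C1=NNCC1c1ccccc1`, has not been measured. It differs from compound 2 by hydrogen in place of methyl on an aromatic carbon. For the measured compounds named here, no measured pair shows this change, so the step from compound 2 to compound 3 is expected to be small, at most a mild weakening, a number 7.1 percentage points lower from compound 2 to compound 3 (within the scatter). Compound 3 is therefore estimated at 38%, within 20% to 55%.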

Compound 3, a percentage reported as activity, at one concentration (the size of the read-out at that concentration, not a potency): "not active" (no number reported)
Compound 3: no number reported; there is nothing to compare the estimate with.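

Compound 3 carries no number, so no step can be read between compound 2 and compound 3. The compounds shown leave open what the change from 4-methylphenyl to phenyl does to activity, and no evidence bears on this result.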